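Swapping a Methoxyphenyl for an Indolyl: Cytotoxicity Outlook

This account rests on a few compounds, and the source may have more. Where it says the series, first, only, none or still open, it means among the compounds named here.

Compound 2 `CCOC(=O)CCCCCOc1cccc(CN(C(=O)c2ccc(-c3cccc(OC)c3)cc2)C(C)C)c1` has been examined in an ADME assay on BJ cells (Homo sapiens) for cytotoxicity, read by CellTiter-Glo and resazurin assay, with a stated time of 72 h; a higher number here means that more compound is needed for the effect, a lower number that less compound is needed. In this assay compound 2 reaches only a limit of the assay, > 21000 nM. Its close relative compound 1 `CCOC(=O)CCCCCOc1cccc(CN(C(=O)c2ccc(-c3cccc(-c4nnc(C)o4)c3)cc2)C(C)C)c1` likewise returns only a limit in this assay, > 26000 nM. The step that the two limits leave unreadable from compound 1 to compound 2 therefore cannot be read. Compound 3 `CCOC(=O)CCCCCOc1cccc(CN(C(=O)c2ccc(-c3ccc4[nH]ccc4c3)cc2)C(C)C)c1` differs from compound 2 by 1H-indol-5-yl in place of 3-methoxyphenyl on an aromatic carbon. Within the data shown here, no measured step offers a readable size; only the two limits the limit of > 21000 nM in this assay, at which 1 of the 2 values shown sits, and the limit of > 26000 nM in this assay, at which 1 of the 2 values shown sits, guide the expectation, so no shift beyond the scatter is anticipated in this assay. Compound 3 is expected to give 30000 nM, within 10000 nM to 100000 nM. The estimated step that the limit leaves unreadable from compound 2 to compound 3 is expected to be essentially flat.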

Compound 3, half-maximal effective concentration: > 26000 nM
Compound 3: no number, only a limit; the forecaster's own chance of this, stated with the estimate: 80%; the middle value does not contradict the limit.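

Compound 3 gives only a limit in this assay, > 26000 nM, so its steps from compound 1 and compound 2, which also return limits, cannot be read. Left open is the concentration at which any of these three compounds reaches the effect, and whether they differ at all.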